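This account rests on a few compounds, and the source may have more. Where it says the series, first, only, none or still open, it means among the compounds named here.

Compound 1 `CC#C[C@H]1CN(S(=O)(=O)c2ccc(N)nc2)CCN1c1ccc(C(=O)NC)cc1`: 41 mL.min-1.g-1
Compound 2 `CC#C[C@H]1CN(S(=O)(=O)c2ccc(N)nc2)CCN1c1ncc(C(C)(O)C(F)(F)F)s1`: 87 mL.min-1.g-1

In an ADME assay (liver) for metabolic stability, with Liver microsome (Rattus norvegicus) as the target, using microsomes and NADPH, with a stated time of 30 min (on this read-out lower numbers stand for slow clearance and higher numbers for fast clearance), compound 1 gives the lower of the two numbers, and compound 2 gives 87 mL.min-1.g-1, which is beyond the usual scatter. Compound 3 `CC#C[C@H]1CN(S(=O)(=O)c2ccc(N)nc2)CCN1c1ccc(S(C)(=N)=O)cc1` is not yet measured. It differs from compound 1 by a group of 4 heavy atoms (1 carbon, 1 nitrogen, 1 oxygen, 1 sulfur; no ring) in place of a group of 4 heavy atoms (2 carbon, 1 nitrogen, 1 oxygen; no ring), on an aromatic carbon. Going by the values given here, no step between measured compounds is known here, so the expected step from compound 1 to compound 3 is put at a 1.2-fold lower number from compound 1 to compound 3 (0.07 log units; within the scatter), not beyond the scatter. On that basis compound 3 is estimated at 35 mL.min-1.g-1, with a range from 15 mL.min-1.g-1 to 80 mL.min-1.g-1.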

Compound 3, intrinsic clearance in microsomes: < 14 mL.min-1.g-1
Compound 3 was reported as a limit; the forecaster's own chance of this, stated with the estimate: 5%; middle value at least 2.5-fold (0.39 log units) from the limit.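

On this aromatic carbon, para to a large group, putting the sulfur-bearing group in place of methylcarbamoyl gives an at least 2.9-fold lower number from compound 1 to compound 3 (0.46 log units; beyond the scatter) in this assay. Going by these compounds alone, this shows for the first time that a change at this one place can shift the read-out beyond the scatter. The size of the step remains a bound, as the value for compound 3 is a limit: the limit of < 14 mL.min-1.g-1 in this assay, at which 1 of the 3 values shown sits.

From the compounds shown here alone, how far the true value of compound 3 lies past that limit remains open. Also open, going by these compounds, is whether a nitrile, a carboxylic acid or an amine on this carbon would give a similar step.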